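This account rests on a few compounds, and the source may have more. Where it says the series, first, only, none or still open, it means among the compounds named here.

Measured so far:
compound 1, `COc1cc(-c2nnc3n2NC(c2ccco2)C(C(=O)C2CC2)S3)cc(OC)c1OC`: > 100000 nM
compound 2, `COc1cc(-c2nnc3n2NC(c2cccs2)C(C(=O)c2ccc(Cl)cc2)S3)cc(OC)c1OC`: 20100 nM

The read-out throughout is a functional assay on A549 cells (Homo sapiens) for cytotoxicity, read by MTT assay, with a stated time of 48 h; on this read-out lower numbers stand for stronger inhibition and higher numbers for weaker inhibition. From the compounds shown here alone, compound 1 gives > 100000 nM, which is a limit of the assay and not a number, so where it truly stands is unknown beyond (the limit of > 100000 nM in this assay, at which 1 of the 2 values shown sits). Compound 2 gives 20100 nM in this assay. For the measured compounds named here, these two compounds differ in more than one place, so no single step between them can be drawn; the two values show only that one is a number and the other a limit.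

Compound 3, `COc1cccc(C(=O)C2Sc3nnc(-c4cc(OC)c(OC)c(OC)c4)n3NC2c2ccco2)c1`, has not yet been measured. It differs from compound 1 by 3-methoxyphenyl in place of cyclopropyl on a carbonyl carbon. Going by the values given here, no measured step matches this change, and since compound 1 stands only at a limit, the size of the move is uncertain. Because compound 2, which also carries an aromatic ring on that carbonyl, gives 20100 nM, a move toward stronger inhibition is expected. The step of an at least 2.5-fold lower number from compound 1 to compound 3 (0.39 log units; beyond the scatter) is expected to run in that direction, beyond the scatter. For compound 3 the expected value is 40000 nM, in the range 10000 nM to 150000 nM.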

Compound 3, half-maximal inhibitory concentration: > 100000 nM
Compound 3 gave a limit, no number; the forecaster's own chance of this, stated with the estimate: 35%; at least 2.5-fold (0.39 log units) between middle value and limit.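

No step can be read from compound 1 to compound 3, because each gives a limit and not a number: the limit of > 100000 nM in this assay, at which 2 of the 3 values shown sit.

What the compounds shown leave open is whether 3-methoxyphenyl in place of cyclopropyl on a carbonyl carbon changes the result in this assay at all, and how far past the limit either compound truly stands.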